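Swapping a disulfide side chain for a hydroxyl on a quinone

The source may hold more compounds than are shown below. What is called first, only, known or untested is meant among the compounds shown, and "the series" means these compounds.

Measured compounds:
Compound 1, `CC1=C([Se]CC(OC(=O)CC[Se]c2ccccc2)C(=O)NCCCCCC(=O)OCc2ccccc2)C(=O)c2ccccc2C1=O`: 9000 nM
Compound 2, `CC1=C([Se]CC(OC(=O)[C@@H](CSSC(C)(C)C)NC(=O)OC(C)(C)C)C(=O)NC(C)(C)C)C(=O)c2ccccc2C1=O`: 3000 nM
Compound 3, `CC1=C(SCCC(=O)OC(C[Se]C2=C(C)C(=O)c3ccccc3C2=O)C(=O)NC(C)(C)C)C(=O)c2ccccc2C1=O`: 3000 nM

All three were tested in a functional assay on MCF7 cells (Homo sapiens) for cytotoxicity, read by MTT assay, with a stated time of 24 h; on this read-out lower numbers stand for stronger inhibition and higher numbers for weaker inhibition. Compound 2 and compound 3 stand level at the digits given, and together they carry the lowest numbers of the three; since their values sit within the usual scatter, no order between them can be read. Compound 1 lies furthest from compound 2, with a number beyond the scatter and therefore a genuinely weaker result.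

The next compound, compound 4, `CC1=C([Se]CC(OC(=O)[C@@H](CO)NC(=O)OC(C)(C)C)C(=O)NC(C)(C)C)C(=O)c2ccccc2C1=O`, keeps the whole framework of compound 2 and changes only the side chain of the amino-acid ester: hydroxy in place of ((tert-butyl)sulfanyl)sulfanyl on a saturated chain carbon, two bonds along the chain from an amide-type nitrogen and a carbonyl carbon. Within the data shown here, no two measured compounds differ in just one place, so no measured step tells how large such a swap is.

Among the measured compounds shown here, removing a sizeable sulfur-bearing branch and leaving a small hydrogen-bond donor in its place gives little ground for a confident direction; the measured set contains no close pair. The expectation is therefore a modest move toward a higher number, close to no change beyond the scatter, as the step of a 1.5-fold higher number from compound 2 to compound 4 (0.18 log units; within the scatter). On this basis compound 4 is expected to give about 4500 nM, within a range from 1500 nM to 14000 nM.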

Compound 4, half-maximal inhibitory concentration: 3000 nM
Estimate against measurement, compound 4: 1.5-fold (0.18 log units) above, and the stated range covers the measured number.
By their numbers in this assay, from the lowest: compounds 2, 3 and 4 (each within the scatter of the next); then compound 1.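

In this assay, the set now holds its first comparison of two compounds that differ in one place, and it reads no change at the digits printed from compound 2 to compound 4 (within the scatter). At this saturated chain carbon, then, a branch of 6 heavy atoms holding 2 sulfur atoms, the ((tert-butyl)sulfanyl)sulfanyl group, can give way to a hydroxy group of 1 heavy atom with no shift that this read-out can distinguish, so the sulfur-bearing branch is not needed to keep the number of compound 2 in this cell test. Nothing measured on these compounds explains why the number holds steady.

Among these compounds, this single step covers only two groups at one position, so it remains open whether an amine, a carboxylic acid or a longer chain ending in a hydroxy group on the same carbon would also leave the number in place. Among the compounds shown here, it is equally open whether the swap from ((tert-butyl)sulfanyl)sulfanyl to hydroxy would read the same way on a different framework from the one shared by compound 2 and compound 4.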